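The compounds below may be only part of what the source reports. "The series", "measured", "known", "first", "only" and "open" are said of these compounds alone.

Compound 1, `Nc1ncnn2c([C@@H]3O[C@H](CO)[C@@H](O)[C@H]3O)cc(-c3ccc(Cl)cc3)c12`: 45900 nM
Compound 2, `Nc1ncnn2c([C@@H]3O[C@H](CO)[C@@H](O)[C@H]3O)cc(-c3ccc(F)cc3F)c12`: 93300 nM

In a functional assay on NCI-H460 cells (Homo sapiens) for antiproliferative activity, with a stated time of 72 h (a lower number here means a stronger inhibitor, a higher number a weaker inhibitor), compound 2 gives the highest of the two numbers recorded; its nearest neighbour is compound 1, and the step of a 2.0-fold higher number from compound 1 to compound 2 (0.31 log units; beyond the scatter) was a modest one, yet beyond the scatter. Compound 3, `Nc1ncnn2c([C@@H]3O[C@H](CO)[C@@H](O)[C@H]3O)cc(-c3ccccc3Cl)c12`, has not been measured in this assay. It differs from compound 2 by 2-chlorophenyl in place of 2,4-difluorophenyl on an aromatic carbon. Going by the values given here, only one measured step exists, the one from compound 1 to compound 2, and it swapped the 4-chlorophenyl for the 2,4-difluorophenyl rather than for a 2-chlorophenyl, so it bears on the present change only loosely: it shows that exchanging one substituted phenyl for another moved the number by a modest amount. Compound 3 is therefore expected to give a step of a 1.7-fold lower number from compound 2 to compound 3 (0.23 log units; within the scatter), toward the lower number seen for compound 1 but with no confidence beyond the scatter. The estimate for compound 3 is 55000 nM, within 20000 nM to 150000 nM.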

Compound 3, half-maximal inhibitory concentration: > 100000 nM
Compound 3 ended at the assay's limit (the forecaster's own chance of this, stated with the estimate: 20%); at least 1.8-fold (0.25 log units) between middle value and limit.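

In this assay, compound 3 reads as a limit of the assay and not as a number: the limit of > 100000 nM in this assay, at which 1 of the 3 values shown sits. Putting the 2-chlorophenyl group in place of the 4-chlorophenyl group gives an at least 2.1-fold higher number from compound 1 to compound 3 (0.33 log units; beyond the scatter), so on this aromatic carbon the place of the chlorine on the phenyl ring changes the result, which the earlier pair could not show because it changed the halogen as well. Against the 2,4-difluorophenyl group the step is an at least 1.0-fold higher number from compound 2 to compound 3 (0.03 log units; that floor lies within the scatter), and no order between these two can be claimed.

All the compounds shown carry a halogenated phenyl group here, so it stays open how a plain phenyl, or a phenyl bearing a methoxy group or an amine, would compare. On these data alone, whether any such group would give a markedly lower number on these cells also stays open.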